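The compounds below may be only part of what the source reports. "The series", "measured", "known", "first", "only" and "open" are said of these compounds alone.

Measured so far:
compound 1 `Cc1nc(S(C)(=O)=O)ccc1Oc1ncnc(OC2CCN(C(=O)OC(C)F)CC2)c1F` — 68%
compound 2 `Cc1nc(S(C)(=O)=O)ccc1Oc1ncnc(OC2CCN(C(=O)OC3COC3)CC2)c1F` — 66%

Both compounds were tested in a functional assay on isolated protein for inhibition of Glucose-dependent insulinotropic receptor (Rattus norvegicus), read by HTRF and cAMP accumulation; a higher number here means a larger maximal response, a lower number a smaller maximal response. Among the measured compounds shown here, compound 1 gives 68% there, and compound 2 gives 66%, the lower of the two numbers; the only change between them is a number 2 percentage points lower from compound 1 to compound 2 (within the scatter), so compound 2 does not stand apart from compound 1 in any real way. Compound 3 `Cc1nc(S(C)(=O)=O)ccc1Oc1ncnc(OC2CCN(C(=O)SC(C)C)CC2)c1F` has not yet been measured. It carries a change at the same carbonyl carbon that the first step touched: isopropylsulfanyl in place of (oxetan-3-yl)oxy on a carbonyl carbon. For the measured compounds named here, the one measured step that bears on this place is a number 2 percentage points lower from compound 1 to compound 2 (within the scatter), and it was a small one. Going by the values given here, nothing in the two numbers at hand points to a change in maximal response from altering the group on this carbonyl carbon, although only a single such step is known and it swapped one oxygen-linked group for another rather than bringing in a sulfur-linked one. For compound 3 the expected step is therefore no change at the digits printed from compound 2 to compound 3 (within the scatter), that is, no move beyond the usual scatter. Compound 3 is estimated to give 66% in this assay, with a likely range from 54% to 78%.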

Compound 3, largest response reached (reported as efficacy), in percent of the reference or control that the assay uses: 81%
Compound 3: the middle estimate sits 15 percentage points below what was measured; measured number above the stated range.
By their numbers in this assay, from the lowest: compounds 2 and 1 (each within the scatter of the next); then compound 3.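

In this assay, the group on the carbonyl carbon can change the maximal response after all: the result is a number 15 percentage points higher from compound 2 to compound 3 (beyond the scatter) with isopropylsulfanyl in place of (oxetan-3-yl)oxy, while the swap between two oxygen-linked groups gave only a number 2 percentage points lower from compound 1 to compound 2 (within the scatter) and so showed no real change. Among the compounds shown here, the other comparison agrees, with a number 13 percentage points higher from compound 1 to compound 3 (beyond the scatter) when the sulfur-linked group replaces the 1-fluoroethyl-bearing oxygen-linked group, so in these three compounds the single sulfur-linked group stands apart from both oxygen-linked ones. Nothing at hand explains this rise in maximal response.

Isopropylsulfanyl differs from the groups it replaces in both its linking atom and its carbon part, so these compounds cannot separate the effect of sulfur from that of the isopropyl group; the matching isopropoxy group would make that comparison directly. From the compounds shown here alone, it also remains open whether a longer sulfur-linked chain such as butylsulfanyl, or a nitrogen-linked group such as isopropylamino on the same carbonyl carbon, would give a similar number in this assay or a different one.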